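The compounds below may be only part of what the source reports. "The series", "measured", "known", "first", "only" and "open" are said of these compounds alone.

Measured so far:
Compound 1, `Nc1nc(OCc2ccccc2)c2[nH]c(O)nc2n1`: in an assay on isolated protein for inhibition of Myeloperoxidase (Homo sapiens), read by fluorescence, with stated times of 10 min, 30 s and 5 min (a higher number here means a weaker inhibitor, a lower number a stronger inhibitor), compound 1 gives > 13000 nM, which is a limit of the assay rather than a number.
Compound 2, `Nc1nc(OCc2ccccc2F)c2nn[nH]c2n1`: in this assay compound 2 gives 78 nM.

Going by the values given here, compound 2 is thus the only compound with a genuine number in this assay; the other entry is a limit, (the limit of > 13000 nM in this assay, at which 1 of the 2 values shown sits). Among the compounds with values here, compounds 1 and 2 differ in more than one place, so no single step can be drawn between them, and their two values show only that compound 2 was measured as a number while compound 1 was not.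

Compound 3, `Nc1nc(OCc2ccccc2Cl)c2nn[nH]c2n1`, has not yet been measured. It differs from compound 2 by chloro in place of fluoro on an aromatic carbon. Within the data shown here, no comparable step between measured compounds exists here, so the expectation rests on the change itself: a small step, not beyond the usual scatter, is expected from compound 2 to compound 3, a 1.3-fold lower number from compound 2 to compound 3 (0.11 log units; within the scatter). Compound 3 is therefore estimated at 60 nM, with a range from 20 nM to 200 nM.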

Compound 3, half-maximal inhibitory concentration: 180 nM
Compound 3: the middle estimate sits 3.0-fold (0.48 log units) below what was measured; measured number inside the range.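

Chloro in place of fluoro on an aromatic carbon gives, in this assay, a 2.3-fold higher number from compound 2 to compound 3 (0.36 log units; beyond the scatter) and this is the first single change that can be read in the series. It shows that this position, on a six-membered aromatic ring of carbon only and ortho to a large group, does respond to an exchange of one halogen for another: the step is modest but lies beyond the usual scatter, and it goes towards the weaker inhibitor. Nothing given here bears on why this exchange moves the number.

Going by these compounds, whether bromo, methyl or methoxy in this place would give a stronger or a weaker inhibitor than fluoro or chloro remains open. So does what plain hydrogen would give on this same core, and with it whether a halogen here helps at all.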